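A few compounds are considered here, and "the series" means these few. Any claim that something is new, unique, unknown or untested is made for them only; others in the source may bear on it.

Measured in a functional assay on M21 cells (Homo sapiens) for antiproliferative activity, read by sulforhodamine B assay, with a stated time of 48 h; on this read-out higher numbers stand for weaker inhibition and lower numbers for stronger inhibition:
- compound 1 `COc1ccccc1OS(=O)(=O)c1ccc(N2CCN(C)C2=O)cc1`: 21000 nM
- compound 2 `COc1cccc(OS(=O)(=O)c2ccc(N3CCN(C)C3=O)cc2)c1`: 1600 nM
- compound 3 `CCN1CCN(c2ccc(S(=O)(=O)Oc3ccccc3OC)cc2)C1=O`: > 100000 nM

Compound 3 reads > 100000 nM, and this is a limit of the assay, not a number. All that can be said is that compound 3 gives no measured value in this assay, so any step starting from it has an uncertain size.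

Compound 4 `CCN1CCN(c2ccc(S(=O)(=O)Oc3cccc(OC)c3)cc2)C1=O` has the same atoms as compound 3, joined differently: 3-methoxyphenyl in place of 2-methoxyphenyl on an oxygen. In words, 3-methoxyphenyl stands in place of 2-methoxyphenyl on an oxygen.

The same swap has been measured once, as a 13-fold lower number from compound 1 to compound 2 (1.12 log units; beyond the scatter). This large step is the most direct guide, although it is a single case. A second step bears on the question: an at least 4.7-fold higher number from compound 1 to compound 3 (0.67 log units; beyond the scatter). It carries the other difference, the added methyl on the chain, and compound 4 has that chain too. Compound 4 should therefore read a higher number than compound 2, which stands at 1600 nM.

Taken together, these two steps lead to the expectation of a large move towards a lower number. The step this estimate means is expected to be an at least 12-fold lower number from compound 3 to compound 4 (1.09 log units; beyond the scatter). The expected value for compound 4 is 8000 nM, with an estimated range from 2000 nM to 40000 nM.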

Compound 4, half-maximal inhibitory concentration: 7000 nM
For compound 4 the middle estimate is 1.1-fold (0.06 log units) above the measured one; the measured number falls inside the stated range.
By their numbers in this assay, from the lowest: compound 2; then compound 4; then compound 1. At a limit, above all of these: compound 3.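

In this assay, 3-methoxyphenyl in place of 2-methoxyphenyl on the oxygen bound to the sulfonyl sulfur gives an at least 14-fold lower number from compound 3 to compound 4 (1.15 log units; beyond the scatter), so the swap now lowers the number on a second core as well: the same change on two cores in this assay, a 13-fold lower number (1.12 log units; beyond the scatter) from compound 1 to compound 2 and an at least 14-fold lower number (1.15 log units; beyond the scatter) from compound 3 to compound 4; the limit leaves it open whether they differ
Compound 3 reads > 100000 nM, which is a limit of the assay and not a number, so this step has a smallest possible size but no exact one.
The added methyl on the chain now has a step with two measured ends, a 4.4-fold higher number from compound 2 to compound 4 (0.64 log units; beyond the scatter), and it points the same way as on the other core: the same change on two cores in this assay, an at least 4.7-fold higher number (0.67 log units; beyond the scatter) from compound 1 to compound 3 and a 4.4-fold higher number (0.64 log units; beyond the scatter) from compound 2 to compound 4; the limit leaves it open whether they differ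

Still open, as far as these compounds go, is what a hydroxyl or an amine would do in place of the methoxy group, and whether a longer chain such as propyl on the amide-type nitrogen would raise the number further. The compounds shown also cannot tell whether the swap has the same size on both cores, or why either change moves the number as it does.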